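Swapping pyridin-3-yl for pyridin-4-yl in compound 1

The source may report more compounds than this note shows. Statements on the series, on what has been measured and on what is new or still open speak of the compounds shown alone.

Measured in a functional assay on SMMC-7721 cells (Homo sapiens) for cytotoxicity, read by MTT assay, with a stated time of 24 h; a lower number here means a stronger inhibitor, a higher number a weaker inhibitor:
Compound 1 `COc1cc(/C=C2\CN(C)C/C(=C\c3cccnc3)C2=O)cc(OC)c1OC`: 20400 nM
Compound 2 `CN1C/C(=C\c2cccnc2)C(=O)/C(=C/c2ccc(F)cc2Br)C1`: 20800 nM
Compound 3 `CN1C/C(=C\c2cccnc2)C(=O)/C(=C/c2ccccc2C(F)(F)F)C1`: 3900 nM

Compound 1 gives 20400 nM and compound 2 gives 20800 nM, two values that lie within the scatter of each other. Compound 3 reads 3900 nM, a lower number than that of compound 1 and beyond the scatter, so it is the stronger inhibitor of that pair.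

The next compound to be tested is compound 4 `COc1cc(/C=C2\CN(C)C/C(=C\c3ccncc3)C2=O)cc(OC)c1OC`. It carries pyridin-4-yl in place of pyridin-3-yl on a double-bonded chain carbon bound to a double-bonded ring carbon. The two compounds have the same atoms, joined differently.

For the measured compounds named here, no two measured compounds differ in one place only, so the data contain no direct measure of such a swap. With so little to go on, no change beyond the scatter is expected in either direction. The expected change is a 1.3-fold lower number from compound 1 to compound 4 (0.11 log units; within the scatter). For compound 4 the estimated value is 16000 nM, with an expected range from 6000 nM to 38000 nM.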

Compound 4, half-maximal inhibitory concentration: 9130 nM
The estimate for compound 4 lay 1.8-fold (0.24 log units) above the measured number, within the range that was stated.
By their numbers in this assay, from the lowest: compound 3; then compound 4; then compounds 1 and 2 (each within the scatter of the next).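

Swapping pyridin-3-yl for pyridin-4-yl on a double-bonded chain carbon bound to a double-bonded ring carbon gives, in this assay, a 2.2-fold lower number from compound 1 to compound 4 (0.35 log units; beyond the scatter). For the compounds shown here, this is the first direct reading of a single change: the two groups have the same atoms and the same counts of donors and acceptors, yet the way they are joined is enough to move the number beyond the scatter. No measurement at hand explains why this swap has that effect.

From the compounds shown here alone, it remains open whether the same swap would give a similar step with the other group of compound 2 or compound 3 in place. Going by these compounds, how a pyridin-2-yl or a plain phenyl group would read at this position is also open.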